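The source may hold more compounds than are shown below. What is called first, only, known or untested is meant among the compounds shown, and "the series" means these compounds.

Measured compounds in a functional assay on UACC-257 cells (Homo sapiens) for inhibition, read by sulforhodamine B assay, with a stated time of 48 h; on this read-out lower numbers stand for higher toxicity in this test and higher numbers for lower toxicity in this test:
compound 1 `Nc1cc(N)c2nc(-c3ccccc3)c(NCc3ccc(Cl)c(Cl)c3)nc2c1`: 43700 nM
compound 2 `COc1ccc(CNc2nc3cc(N)cc(N)c3nc2-c2ccccc2)cc1OC`: 55000 nM
compound 3 `Nc1cc(N)c2nc(-c3ccccc3)c(NCc3ccc(F)cc3)nc2c1`: 8910 nM

Compound 3 gives the lowest number of the three, set apart by the steps of a 4.9-fold lower number from compound 1 to compound 3 (0.69 log units; beyond the scatter) and a 6.2-fold lower number from compound 2 to compound 3 (0.79 log units; beyond the scatter), while the step of a 1.3-fold higher number from compound 1 to compound 2 (0.10 log units; within the scatter) is within the scatter. Compound 4 `Nc1cc(N)c2nc(-c3ccccc3)c(Oc3ccc(F)cc3)nc2c1` differs from compound 3 by 4-fluorophenoxy in place of (4-fluorobenzyl)amino on an aromatic carbon. Among the compounds with values here, no measured step touches this change: the three steps so far only swap the ring that hangs off the benzyl group, leaving the amino link in place. There is no basis for a confident direction, so a small step is expected, leaning towards a higher number for compound 4 than for compound 3, a 2.2-fold higher number from compound 3 to compound 4 (0.35 log units; beyond the scatter). Compound 4 is estimated at 20000 nM, within 5000 nM to 80000 nM.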

Compound 4, concentration lethal to 50% of the cells: 77600 nM
For compound 4 the middle estimate is 3.9-fold (0.59 log units) below the measured one; the measured number falls inside the stated range.
By their numbers in this assay, from the lowest: compound 3; then compounds 1, 2 and 4 (each within the scatter of the next).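

The earlier steps shown here only swapped the ring on the benzyl group, whereas this one changes the link to the shared core, and in this assay it gives an 8.7-fold higher number from compound 3 to compound 4 (0.94 log units; beyond the scatter). So at this aromatic carbon the link matters as well as the ring it carries, though the 4-fluorophenoxy group differs from (4-fluorobenzyl)amino both in lacking a hydrogen-bond donor and in having fewer heavy atoms, and this step cannot separate the two. Nothing shown explains the step.

Still open, on these data alone, is how a methylamino or thioether link at this carbon would compare. As far as these compounds go, it is also open whether the same swap would move the number similarly with the 3,4-dichlorophenyl or 3,4-dimethoxyphenyl ring.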